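Sulfanyl to phenoxy link: compound 3 to compound 4

A few compounds are considered here, and "the series" means these few. Any claim that something is new, unique, unknown or untested is made for them only; others in the source may bear on it.

The series shares the core of compound 1 `Nc1cc(N)c2nc(-c3ccccc3)c(Oc3ccc(Cl)c(Cl)c3)nc2c1`, which in a functional assay on NCI-H460 cells (Homo sapiens) for inhibition, read by sulforhodamine B assay, with a stated time of 48 h (a higher number here means a weaker inhibitor of growth, a lower number a stronger inhibitor of growth), gives 18200 nM. Compound 2 `CCOC(=O)[C@H](CCC(=O)O)NC(=O)c1ccc(Sc2nc3cc(N)cc(N)c3nc2-c2ccccc2)cc1`, carrying a much larger group, gives 27500 nM. Compound 3 `Nc1cc(N)c2nc(-c3ccccc3)c(Sc3ccc(F)cc3)nc2c1` gives 21900 nM; this number lies within the scatter of both compound 1 and compound 2, so the three measured numbers cannot be told apart. Going by the values given here, the only single-place step among them is a 1.2-fold higher number from compound 1 to compound 3 (0.08 log units; within the scatter), which changes both the linking group and the ring substituents at once and stays within the scatter.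

Compound 4 `Nc1cc(N)c2nc(-c3ccccc3)c(Oc3ccc(F)cc3)nc2c1` differs from compound 3 by 4-fluorophenoxy in place of (4-fluorophenyl)sulfanyl on an aromatic carbon. Among the compounds with values here, no measured step isolates this exchange alone; the step from compound 1 to compound 3 is the nearest comparison, and it was flat. A step of a 1.0-fold lower number from compound 3 to compound 4 (0.02 log units; within the scatter) is therefore expected, which is nothing beyond the scatter. Compound 4 is estimated at 21000 nM in this assay, with a range from 8000 nM to 55000 nM.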

Compound 4, concentration for 50% growth inhibition: 39800 nM
The estimate for compound 4 lay 1.9-fold (0.28 log units) below the measured number; measured number inside the range.
By their numbers in this assay, from the lowest: compounds 1, 3, 2 and 4 (each within the scatter of the next, the first and the last beyond it).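

In this assay, going by these compounds alone, the step with the 4-fluorophenyl ring held constant, a 1.8-fold higher number from compound 3 to compound 4 (0.26 log units; within the scatter), is the first reading of the link alone, and sulfanyl and phenoxy cannot be told apart at this carbon next to the ring nitrogen. With the oxygen link held constant, 4-fluorophenyl in place of 3,4-dichlorophenyl gives a 2.2-fold higher number from compound 1 to compound 4 (0.34 log units; beyond the scatter), the only step shown that lies beyond the scatter, and it is modest. No available evidence bears on the origin of either step.

Open, on these data alone, is whether an amine link to the same 4-fluorophenyl ring would read with the sulfanyl and phenoxy compounds, or a carboxylic acid on that ring would shift the number beyond the scatter. Also open, as far as these compounds go, is whether the change from 3,4-dichlorophenyl to 4-fluorophenyl gives a similar step on a sulfur link.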